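Chloro for bromo on the core of compound 1

A few compounds are considered here, and "the series" means these few. Any claim that something is new, unique, unknown or untested is made for them only; others in the source may bear on it.

The two measured compounds share one core and differ in a single place. Compound 1 `Brc1cccc2c1nnn2CC1CC1` carries a bromo group on an aromatic carbon; compound 2 `Fc1cc(Br)c2nnn(CC3CC3)c2c1` adds a fluoro group on another aromatic carbon of the same core. In a functional assay on cells for positive allosteric modulation of metabotropic glutamate receptor 2 (Homo sapiens), read by fluorescence and calcium flux, with a stated time of 30 min (a higher number here means that more compound is needed for the effect, a lower number that less compound is needed), compound 1 gives 70 nM, and in this assay compound 2 gives 70 nM. The step of no change at the digits printed from compound 1 to compound 2 (within the scatter) shows that the added fluoro left the read-out unchanged, so compound 1 stands level with compound 2 at the digits shown, with no other neighbour to place it against.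

Compound 3 `Clc1cccc2c1nnn2CC1CC1` is the unmeasured analogue. The change from compound 1 is chloro in place of bromo on an aromatic carbon. Going by the values given here, no measured step exchanges one halogen for another; the only step recorded, from compound 1 to compound 2, concerns a different place and a different kind of change, and it was flat. On that thin basis a small step is expected, if any, most likely toward a somewhat higher half-maximal effective concentration: a 1.6-fold higher number from compound 1 to compound 3 (0.20 log units; within the scatter). Compound 3 is therefore estimated at 110 nM in this assay, within a range from 40 nM to 300 nM.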

Compound 3, half-maximal effective concentration: 90 nM
The estimate for compound 3 lay 1.2-fold (0.09 log units) above the measured number; measured number inside the range.
By their numbers in this assay, from the lowest: compounds 1, 2 and 3 (each within the scatter of the next).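

In this assay, going by these compounds alone, the exchange of one halogen for another at this place gives a 1.3-fold higher number from compound 1 to compound 3 (0.11 log units; within the scatter), the first direct reading of a change at the aromatic carbon that carries the bromo group, since the earlier step concerned a fluoro group at another place on the shared core. The assay therefore does not separate bromo from chloro here, and within these two compounds, the chloro group serves as well as the bromo group at this position. No measurement shown here offers an explanation for this result.

The compounds shown leave open how far this tolerance extends, as both groups at this place are halogens and neither has a hydrogen-bond donor or acceptor under the count given for the exchange. Whether an amine, a nitrile or a carboxylic acid on the same aromatic carbon would keep the read-out in the same range remains unanswered, as does whether the fluoro group of compound 2 would stay without effect alongside chloro rather than bromo.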